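The source may report more compounds than this note shows. Statements on the series, on what has been measured and on what is new or still open speak of the compounds shown alone.

Measured compounds:
- compound 1 `Cc1ccc(NC2=CC(=O)c3nc4n(c3C2=O)[C@H]2OC[C@@H](O)[C@H]2OC4)cc1` — in a functional assay on ECa-109 cells for inhibition, with ECa-109 cell line (Homo sapiens) as the target, read by sulforhodamine B assay (on this read-out higher numbers stand for weaker inhibition and lower numbers for stronger inhibition), compound 1 gives 3480 nM
- compound 2 `O=C1C(Nc2cccc(Cl)c2)=CC(=O)c2c1nc1n2[C@H]2OC[C@@H](O)[C@H]2OC1` — compound 2 gives 3080 nM
- compound 3 `O=C1C=C(Nc2ccccc2)C(=O)c2c1nc1n2[C@H]2OC[C@@H](O)[C@H]2OC1` — compound 3 gives 4970 nM

Compound 2 gives the lowest number of the three, but its gap to compound 1 and its gap to compound 3 are both within the scatter, so the three cannot be told apart on these numbers. For the measured compounds named here, the one measured step, a 1.4-fold higher number from compound 1 to compound 3 (0.15 log units; within the scatter), alters the substituent on the anilino ring and leaves the read-out essentially unchanged.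

Compound 4 `O=C1C(Nc2ccc(C(F)(F)F)cc2)=CC(=O)c2c1nc1n2[C@H]2OC[C@@H](O)[C@H]2OC1` is not yet measured. The change from compound 2 is 4-(trifluoromethyl)phenyl in place of 3-chlorophenyl on an amine nitrogen. Going by the values given here, no measured step swaps chlorine for trifluoromethyl; the only step that bears on it, the substituent change from compound 1 to compound 3, was within the scatter. On that basis no step beyond the scatter is expected in this assay.

Compound 4 is expected to give about 3500 nM in this assay, with a range of 1500 nM to 8000 nM, a step of a 1.1-fold higher number from compound 2 to compound 4 (0.06 log units; within the scatter) that is estimated, not measured.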

Compound 4, half-maximal inhibitory concentration: 2250 nM
Beside the measured number, compound 4's estimate is 1.6-fold (0.19 log units) above it; measured number inside the range.
By their numbers in this assay, from the lowest: compounds 4, 2, 1 and 3 (each within the scatter of the next, the first and the last beyond it).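

In this assay, for the compounds shown here, a 1.4-fold lower number from compound 2 to compound 4 (0.14 log units; within the scatter) is the first measured change that replaces both the substituent and the aryl group's substitution pattern on the amine nitrogen. The read-out stays within the scatter even though 4-(trifluoromethyl)phenyl has more heavy atoms than 3-chlorophenyl, so this position accepts trifluoromethyl as well as chlorine, at least across compound 2 and compound 4. Nothing available accounts for the result or separates the contributions of the substituent and its placement on the ring.

Going by these compounds, all four compounds carry a phenyl ring on the amine nitrogen, so the effect of a basic amine or a carboxylic acid on that ring remains open. Also open, on these data alone, is whether a saturated ring such as cyclohexyl, or a simple alkyl chain, can take the place of the phenyl ring.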